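Swapping 4-methoxyphenyl for 3-chlorophenyl on the shared core

A few compounds are considered here, and "the series" means these few. Any claim that something is new, unique, unknown or untested is made for them only; others in the source may bear on it.

Compound 1 `Oc1ccc(-c2ccc(-c3ccc(-c4nc5c(O)cccc5[nH]4)cc3)cc2)cc1` stands at 2650 nM
Compound 2 `COc1ccc(-c2ccc(-c3ccc(-c4nc5c(O)cccc5[nH]4)cc3)cc2)cc1` stands at 8200 nM

Within the data shown here, both numbers come from a functional assay on ZR-75-1 cells (Homo sapiens) for inhibition, read by sulforhodamine B assay (on this read-out lower numbers stand for stronger inhibition of growth and higher numbers for weaker inhibition of growth), and compound 2 holds the higher of the two, with compound 1 as its only neighbour. Compound 3 `Oc1cccc2[nH]c(-c3ccc(-c4ccc(-c5cccc(Cl)c5)cc4)cc3)nc12` keeps the shared core but has 3-chlorophenyl in place of 4-methoxyphenyl on an aromatic carbon and has not yet been measured. Among the measured compounds shown here, the one measured step bearing on this is a 3.1-fold higher number from compound 1 to compound 2 (0.49 log units; beyond the scatter) with methyl in place of hydrogen on an oxygen on an aromatic ring. For the measured compounds named here, that modest step touches only the group that leaves here, and no measured compound carries 3-chlorophenyl, so it gives size but no firm direction. In this assay a step of similar size is therefore expected, leaning slightly towards a lower number. The estimated step is a 1.5-fold lower number from compound 2 to compound 3 (0.17 log units; within the scatter) and remains uncertain. Compound 3 is estimated at 5500 nM with a range from 1800 nM to 16000 nM as the expected span.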

Compound 3, concentration for 50% growth inhibition: 2410 nM
Compound 3: middle estimate off by 2.3-fold (0.36 log units), on the high side; the measured number falls inside the stated range.
By their numbers in this assay, from the lowest: compounds 3 and 1 (each within the scatter of the next); then compound 2.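

In this assay the replacement at this aromatic carbon gives a 3.4-fold lower number from compound 2 to compound 3 (0.53 log units; beyond the scatter) and so shows that the position responds to an exchange of the whole ring, where the earlier step touched only the methyl on the oxygen. Against the 4-hydroxyphenyl of compound 1 the same position gives a 1.1-fold lower number from compound 1 to compound 3 (0.04 log units; within the scatter) and thus 3-chlorophenyl and 4-hydroxyphenyl cannot be told apart here, which leaves compound 2 with its 4-methoxyphenyl as the only one of the three set off from the others. Nothing given here accounts for this result.

The compounds shown leave open whether the chlorine or its place on the ring carries the step, as they include neither 4-chlorophenyl nor 3-methoxyphenyl. They also say nothing of how an amine or a carboxylic acid on this ring would read.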